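The compounds below may be only part of what the source reports. "The series", "measured", "known", "first", "only" and "open" are said of these compounds alone.

Working notes on the series.

Compound 1 `CCOC(=O)N1N=C(c2cccc(OC)c2)CC1c1cc(OC)c(OC)c(OC)c1` in a functional assay on HT-29 cells (Homo sapiens) for antiproliferative activity, read by MTT assay, with a stated time of 48 h (on this read-out higher numbers stand for weaker inhibition of growth and lower numbers for stronger inhibition of growth), gives 7860 nM. For compound 2 `CCCOC(=O)N1N=C(c2cccc(OC)c2)CC1c1cc(OC)c(OC)c(OC)c1` this assay reports only a limit, > 10000 nM. Compound 3 `CCOC(=O)N1N=C(c2cccc(O)c2)CC1c1cc(OC)c(OC)c(OC)c1` in this assay gives 11600 nM. Compound 4 `CCCOC(=O)N1N=C(c2cccc(O)c2)CC1c1cc(OC)c(OC)c(OC)c1` is not yet measured in this assay.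

The change shared by two pairs is methyl in place of hydrogen on a saturated chain carbon, two bonds along the chain from an oxygen next to a carbonyl group. Between the measured pair it made an at least 1.2-fold higher number from compound 1 to compound 2 (0.10 log units; that floor lies within the scatter); the step is known only as a floor because of the limit of > 10000 nM in this assay, at which 1 of the 3 values shown sits, so the true size is open. The cores of compound 3 and compound 1 differ by hydrogen in place of methyl on an oxygen on an aromatic ring, which gave a 1.5-fold higher number from compound 1 to compound 3 (0.17 log units; within the scatter). The same change is now to be read from compound 3 to compound 4, written as methyl in place of hydrogen on a saturated chain carbon, two bonds along the chain from an oxygen next to a carbonyl group; the place is the same in both pairs word for word, so this is the same change.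

Expected for compound 4: a step of about a 1.5-fold higher number from compound 3 to compound 4 (0.17 log units; within the scatter), on the footing that compound 3 already sits at 11600 nM and the same change was read between compound 1 and compound 2. Compound 4 is therefore expected to give around 17000 nM in this assay, likely between 9000 nM and 40000 nM, and very possibly only a limit.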

Compound 4, concentration for 50% growth inhibition: 15200 nM
Beside the measured number, compound 4's estimate is 1.1-fold (0.05 log units) above it; measured number inside the range.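

In this assay, the change of ethoxy to propoxy on the core of compound 3 gives a 1.3-fold higher number from compound 3 to compound 4 (0.12 log units; within the scatter). Set beside the reading on the core of compound 1, the two steps stand as follows: the same change on two cores in this assay, an at least 1.2-fold higher number (0.10 log units; that floor lies within the scatter) from compound 1 to compound 2 and a 1.3-fold higher number (0.12 log units; within the scatter) from compound 3 to compound 4; the limit leaves it open whether they differ. Neither core shows a step beyond the scatter, so the change carries across these two cores without a visible shift in growth inhibition, but equal step sizes on the two cores are not shown, and the step from compound 2 to compound 4 cannot be read, as compound 2 is known only as a limit: the limit of > 10000 nM in this assay, at which 1 of the 4 values shown sits.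

The compounds shown leave open whether a longer chain than propyl at the same place, or one ending in an amine or a carboxylic acid, would give a step beyond the scatter. They also leave open whether the change reads the same on a core where the oxygen on the aromatic ring carries an ethyl group.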